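Working notes: from compound 2 to a biphenylmethyl analogue

The source may hold more compounds than are shown below. What is called first, only, known or untested is meant among the compounds shown, and "the series" means these compounds.

Compound 2 `COc1ccccc1N1CCN(CCCNC(=O)NN(Cc2ccccc2F)c2ccc(F)cc2)CC1` gives 3.6 nM in an assay on CHO cells for displacement of a labelled ligand from D(4) dopamine receptor (Homo sapiens), read by radioligand binding; a higher number here means a weaker inhibitor, a lower number a stronger inhibitor. Compound 1 `COc1ccccc1N1CCN(CCCCNC(=O)NN(Cc2ccccc2)c2ccc(F)cc2)CC1` gives 4.4 nM in this assay. Compound 2 holds the lower of the two numbers, but the gap to compound 1 lies within the scatter, so the two compounds cannot be ordered against each other; both read as strong inhibitors.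

Compound 3 `COc1ccccc1N1CCN(CCCNC(=O)NN(Cc2ccc(-c3ccccc3)cc2)c2ccc(F)cc2)CC1` has not yet been measured in this assay. It differs from compound 2 in one place: 4-phenylphenyl in place of 2-fluorophenyl on a saturated chain carbon bound to a nitrogen on an aromatic ring. Going by the values given here, no step between measured compounds covers a change of this kind, so the series gives no direct read on its size. The two measured numbers show that the position on the saturated chain carbon accepts both a 2-fluorophenyl and a plain phenyl without loss, which argues against a large penalty, while a change as large as 4-phenylphenyl leaves room for a moderate rise in the inhibition constant. A step of a 2.2-fold higher number from compound 2 to compound 3 (0.35 log units; beyond the scatter) is expected, at most a modest weakening and possibly none beyond the scatter. Compound 3 is therefore estimated at 8 nM, with a range from 2 nM to 30 nM.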

Compound 3, inhibition constant: 5.9 nM
Estimate against measurement, compound 3: 1.4-fold (0.13 log units) above, within the range that was stated.
By their numbers in this assay, from the lowest: compounds 2, 1 and 3 (each within the scatter of the next).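

In this assay the exchange of 2-fluorophenyl for 4-phenylphenyl on a saturated chain carbon bound to a nitrogen on an aromatic ring gives a 1.6-fold higher number from compound 2 to compound 3 (0.21 log units; within the scatter) and so leaves the two compounds unordered. Going by these compounds alone, this is the first step that can be read at one place, and it shows that the position takes 4-phenylphenyl, with 12 heavy atoms and 2 six-membered aromatic rings of carbon only, in place of 2-fluorophenyl, with 7 heavy atoms and one such ring, without a step beyond the scatter. No measured information on either group bears on this result.

The compounds shown hold only aromatic carbon rings at this place, so it remains open whether an amine, a carboxylic acid or a longer saturated chain carrying a morpholine would be taken as well. Going by these compounds, it is also open whether the same exchange would give a comparable step on the core of compound 1, since a single pair of compounds speaks for this change.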